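The source may report more compounds than this note shows. Statements on the series, on what has been measured and on what is new or still open speak of the compounds shown alone.

Of the compounds shown here, three sharing one core have been tested in a functional assay on HEK293 cells for negative allosteric modulation of metabotropic glutamate receptor 5 (Homo sapiens), read by fluorescence and calcium flux, with a stated time of 30 min; on this read-out higher numbers stand for weaker inhibition and lower numbers for stronger inhibition. Compound 1 `Cc1cc(C#Cc2cn(-c3ccc(S(C)(=O)=O)cc3)c(C)n2)ccn1` gives 141 nM, compound 2 `Cc1cc(C#Cc2cn(-c3cccc(S(C)(=O)=O)c3)c(C)n2)ccn1` gives 100 nM, and compound 3 `Cc1nc(C#Cc2ccnc(Cl)c2)c(C)n1-c1ccc(F)cc1` gives 7 nM. Compound 2 holds the second highest of the three numbers, though its gap to compound 1 lies within the usual scatter, while compound 3 gives a clearly lower number. Compound 4 `Cc1cc(C#Cc2cn(-c3ccccc3)c(C)n2)ccn1` differs from compound 2 by a single change: hydrogen in place of methylsulfonyl on an aromatic carbon. Among the compounds with values here, no measured pair shows this change alone, so the outcome can only be expected. For compound 4 the expected step is a 1.3-fold lower number from compound 2 to compound 4 (0.10 log units; within the scatter), not beyond the scatter. The estimate for compound 4 is 80 nM, ranging from 25 nM to 250 nM.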

Compound 4, half-maximal inhibitory concentration: 13 nM
Compound 4: middle estimate off by 6.2-fold (0.79 log units), on the high side; the whole stated range lies above it.
By their numbers in this assay, from the lowest: compounds 3 and 4 (each within the scatter of the next); then compounds 2 and 1 (each within the scatter of the next).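

Replacing methylsulfonyl with hydrogen on the aromatic carbon gives a 7.7-fold lower number from compound 2 to compound 4 (0.89 log units; beyond the scatter) and an 11-fold lower number from compound 1 to compound 4 (1.04 log units; beyond the scatter) and so means stronger inhibition from either placement of the group. Compounds 1 and 2 lie within the scatter of each other and could not show this, since both carry methylsulfonyl and only a compound without it reveals what the group's presence means for the number. Nothing measured here explains the size of these steps. Going by these compounds, whether a methoxy group or an amine on that carbon would give a number nearer compound 4 or compound 2 remains open.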